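The compounds below may be only part of what the source reports. "The series", "measured", "known", "first", "only" and "open" are said of these compounds alone.

Measured compounds:
compound 1, `Cn1c(-c2ccccc2)nnc1S(C)(=O)=O`, gives 55 mg/kg.
compound 2, `Cn1c(-c2ccccc2F)nnc1S(C)(=O)=O`, gives only a limit, > 100 mg/kg.
compound 3, `Cn1nc(-c2ccccc2)nc1S(C)(=O)=O`, gives only a limit, > 200 mg/kg.

Compound 1 was tested in a functional assay on the whole organism for antagonist activity, with Mus musculus as the target (on this read-out higher numbers stand for an effect only at larger amounts of compound and lower numbers for an effect already at smaller amounts), and gave 55 mg/kg. Compound 2 differs from compound 1 in one place: fluoro in place of hydrogen on an aromatic carbon. In this assay compound 2 reached only a limit, > 100 mg/kg. The step is therefore known only as a floor, an at least 1.8-fold higher number from compound 1 to compound 2 (0.25 log units; that floor lies within the scatter), and the value of compound 2 sits at the limit of > 100 mg/kg in this assay, at which 1 of the 3 values shown sits. Compound 3 is built from the same atoms as compound 1, joined differently; the difference between the two cores is not broken down here. In this assay compound 3 also gave only a limit, > 200 mg/kg, which is the limit of > 200 mg/kg in this assay, at which 1 of the 3 values shown sits.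

Compound 4, `Cn1nc(-c2cccc(F)c2)nc1S(C)(=O)=O`, stands to compound 3 as compound 2 stands to compound 1: fluoro in place of hydrogen on an aromatic carbon. The place is not the same word for word: in compound 2 the fluoro sits ortho to a large group, in compound 4 meta to a large group, so this is the same kind of change, not the same change. In this assay, for the measured compounds named here, the step is expected to be about a step that the limit leaves unreadable from compound 3 to compound 4, resting on the single earlier instance, which gave the floor an at least 1.8-fold higher number from compound 1 to compound 2 (0.25 log units; that floor lies within the scatter). Compound 4 is therefore expected to give about 350 mg/kg, between 120 mg/kg and 1000 mg/kg, and the assay is likely to report only a limit for compound 4 again.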

Compound 4, dose for half-maximal effect: > 100 mg/kg
Compound 4: no number, only a limit; the forecaster's own chance of this, stated with the estimate: 75%; the middle value lies beyond the limit too.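

In this assay compound 3 and compound 4 both give only a limit, and the step between them cannot be read. The compounds shown leave open where the true values of these two compounds lie, and whether fluoro in place of hydrogen on an aromatic carbon moves the read-out on the core of compound 3 in the same direction as on the core of compound 1.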